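This account rests on a few compounds, and the source may have more. Where it says the series, first, only, none or still open, it means among the compounds named here.

Measured in a functional assay on SW480 cells (Homo sapiens) for antiproliferative activity, read by MTT assay, with a stated time of 48 h; on this read-out higher numbers stand for weaker inhibition and lower numbers for stronger inhibition:
- Compound 1 `CCCCCCCCCC(CCO)n1cnc2c(Cl)ncnc21`: 1150 nM
- Compound 2 `CCCCCCCCCC(CCn1cc(-c2ccccc2)nn1)n1cnc2c(Cl)ncnc21`: 9920 nM

Of these two compounds, compound 2 has the higher number and so the weaker inhibition. Compound 3 `CCCCCCCCCC(CCCl)n1cnc2c(Cl)ncnc21` differs from compound 2 as follows: chloro in place of 4-phenyl-1H-1,2,3-triazol-1-yl on a saturated chain carbon, three bonds along the chain from an aromatic nitrogen. In words, it carries chloro in place of 4-phenyl-1H-1,2,3-triazol-1-yl on a saturated chain carbon, three bonds along the chain from an aromatic nitrogen.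

Within the data shown here, only one measured step bears on this change: an 8.6-fold higher number from compound 1 to compound 2 (0.94 log units; beyond the scatter). That step brought in the same 4-phenyl-1H-1,2,3-triazol-1-yl group, there in place of hydroxy. No chloro at this place has been measured, so the step offers only a rough guide. Removing the group is expected to give a step of similar or somewhat smaller size towards a lower number.

The expected change is a 5.0-fold lower number from compound 2 to compound 3 (0.70 log units; beyond the scatter). For compound 3, the estimated value is 2000 nM, with an expected range of 700 nM to 6000 nM.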

Compound 3, half-maximal inhibitory concentration: 7180 nM
Beside the measured number, compound 3's estimate is 3.6-fold (0.56 log units) below it; measured number above the stated range.
By their numbers in this assay, from the lowest: compound 1; then compounds 3 and 2 (each within the scatter of the next).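

In this assay the exchange of 4-phenyl-1H-1,2,3-triazol-1-yl for chloro gives a 1.4-fold lower number from compound 2 to compound 3 (0.14 log units; within the scatter) and so separates neither group from the other at this place, even though the group that leaves has 11 heavy atoms and the one that enters has a single chlorine. Hydroxy now stands apart from both groups, since chloro in its place gives a 6.2-fold higher number from compound 1 to compound 3 (0.80 log units; beyond the scatter) and so moves the number in the same direction as the triazole did. Nothing shown here gives a reason for this result.

On these data alone, whether an amine or a methoxy group on this carbon would stay with hydroxy or with the other two groups remains open. So does whether a carboxylic acid or a longer chain ending in hydroxy would give a lower number than compound 1 does.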